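Swapping the benzyl arm for a dichlorophenyl thiourea

This account rests on a few compounds, and the source may have more. Where it says the series, first, only, none or still open, it means among the compounds named here.

Compound 1 `Cc1ccccc1CN1CCc2c(sc(NC(=O)c3ccccc3Cl)c2C(N)=O)C1` belongs to a small set tested in a functional assay on HeLa cells (Homo sapiens) for antiproliferative activity, with a stated time of 24 h; on this read-out lower numbers stand for stronger inhibition and higher numbers for weaker inhibition. Compound 1 returns only a limit, > 50000 nM, and so stands at the limit of > 50000 nM in this assay, at which 1 of the 2 values shown sits. Compound 2 `NC(=O)c1c(NC(=O)c2ccccc2Cl)sc2c1CCN(C(=S)Nc1cccc3ccccc13)C2` gives 30800 nM in this assay. Compound 3 `NC(=O)c1c(NC(=O)c2ccccc2Cl)sc2c1CCN(C(=S)Nc1c(Cl)cccc1Cl)C2` is compound 1 with a group of 11 heavy atoms (7 carbon, 1 nitrogen, 1 sulfur, 2 chlorine; one six-membered aromatic ring of carbon only) in place of a group of 8 heavy atoms (8 carbon; one six-membered aromatic ring of carbon only), on an amine nitrogen in a ring. Going by the values given here, no measured step matches this change, and in this assay a shift no larger than the usual scatter, in neither direction, is expected. Compound 3 is expected at 40000 nM, within a range from 15000 nM to 100000 nM, an estimated step of an at least 1.2-fold lower number from compound 1 to compound 3 (0.09 log units; that floor lies within the scatter) that may again end at the limit.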

Compound 3, half-maximal inhibitory concentration: 26500 nM
For compound 3 the middle estimate is 1.5-fold (0.18 log units) above the measured one, within the range that was stated.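

Compound 1 holds only a limit in this assay, not a number: the limit of > 50000 nM in this assay, at which 1 of the 3 values shown sits. Replacing its 2-methylbenzyl on the amine nitrogen in a ring can therefore be read only as a floor, an at least 1.8-fold lower number from compound 1 to compound 3 (0.27 log units; that floor lies within the scatter), so no shift beyond the scatter can be claimed for this change. Placing 2,6-dichlorophenyl instead of naphthalen-1-yl on the amide-type nitrogen gives a 1.2-fold lower number from compound 2 to compound 3 (0.07 log units; within the scatter), so these two groups are not told apart here.

On these data alone, whether the thiourea arm truly differs from the benzyl arm stays open, as does what a plain phenyl or a butyl chain would give on that thiourea nitrogen.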